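The source may report more compounds than this note shows. Statements on the series, on what has been measured and on what is new or still open speak of the compounds shown alone.

In an ADME assay on L6 cells (Rattus norvegicus) for cytotoxicity, read by resazurin assay, with a stated time of 72 h (a lower number here means a stronger inhibitor, a higher number a weaker inhibitor), compound 3 (`N=C(N)c1ccc(COc2ccccc2)cc1`) gives 167000000 nM and compound 2 (`N=C(N)c1cccc(OCc2ccccc2)c1`) gives 156000000 nM, two values within the usual scatter of each other. Compound 1 (`N=C(N)c1cc(I)c(OCc2cccc([N+](=O)[O-])c2)c(I)c1`) gives 7720000 nM, a lower number than either, and beyond the scatter. Compound 4 (`CC(C)c1ccc(OCc2ccc(C(=N)N)cc2)cc1`) differs from compound 3 by one change, isopropyl in place of hydrogen on an aromatic carbon. For the measured compounds named here, no measured pair shows this change, so the expectation rests only on the spread from compound 1 at 7720000 nM to compound 3 at 167000000 nM. A moderate move towards a lower number is expected, an estimated 3.7-fold lower number from compound 3 to compound 4 (0.57 log units; beyond the scatter). For compound 4 the estimated value is 45000000 nM, with an expected range from 12000000 nM to 160000000 nM.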

Compound 4, half-maximal inhibitory concentration: 5360000 nM
For compound 4 the middle estimate is 8.4-fold (0.92 log units) above the measured one; the measured number lies below the stated range.
By their numbers in this assay, from the lowest: compounds 4 and 1 (each within the scatter of the next); then compounds 2 and 3 (each within the scatter of the next).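

In this assay, isopropyl in place of hydrogen on an aromatic carbon, para to a large group, gives a 31-fold lower number from compound 3 to compound 4 (1.49 log units; beyond the scatter), a large step. For the compounds shown here, the earlier compounds offered no single change to read, so this is the first sign that this position is not indifferent in this assay. One added isopropyl is enough to carry the number well beyond the scatter.

From the compounds shown here alone, whether a methyl, a longer chain or an amine at this position would move the number in the same way remains open. Nothing shown gives a reason for this step.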